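The source may report more compounds than this note shows. Statements on the series, on what has been measured and on what is new or still open speak of the compounds shown alone.

Working notes on the series. Compound 2 `COc1cc(NC(C)CCCNC(=O)Nc2ccc(Cl)c(C(F)(F)F)c2)c2ncccc2c1` gives 4000 nM in a functional assay on MIA PaCa-2 cells (Homo sapiens) for inhibition, read by MTT assay, with a stated time of 4 days (on this read-out higher numbers stand for weaker inhibition and lower numbers for stronger inhibition), the lowest of the three numbers in hand. Compound 1 `COc1ccc(C(=NNC(=O)NNC(=O)NCCCC(C)Nc2cc(OC)cc3cccnc23)c2ccc(OC)cc2)cc1` gives 11000 nM in this assay, and compound 3 `COc1cc(NC(C)CCCNC(=O)N(C)C(c2ccccc2)c2ccccc2)c2ncccc2c1` gives 21000 nM in this assay; both gaps to compound 2 lie beyond the scatter. Compound 4 `COc1cc(NC(C)CCCNC(=O)NNC(=O)NCCCO)c2ncccc2c1` is not yet measured. It differs from compound 2 in one place (((3-hydroxypropyl)carbamoyl)amino in place of 4-chloro-3-(trifluoromethyl)phenyl on an amide-type nitrogen). Within the data shown here, no single-change step among measured compounds is available for this change; the only orientation is compound 1, which carries a related ((3-hydroxypropyl)carbamoyl)amino-type motif and gives 11000 nM. Compound 4 is therefore expected to move toward weaker inhibition, a step of a 3.0-fold higher number from compound 2 to compound 4 (0.48 log units; beyond the scatter), with an estimate of 12000 nM in this assay and a range from 4000 nM to 40000 nM.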

Compound 4, half-maximal inhibitory concentration: >= 250000 nM
Compound 4 ended at the assay's limit (the forecaster's own chance of this, stated with the estimate: 15%); at least 20-fold (1.31 log units) between middle value and limit.
By their numbers in this assay, from the lowest: compound 2; then compounds 1 and 3 (each within the scatter of the next). At a limit, above all of these: compound 4.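

Compound 4 reads as a limit of this assay, not as a number: the limit of >= 250000 nM in this assay, at which 1 of the 4 values shown sits. Among these compounds, the first single-change step, ((3-hydroxypropyl)carbamoyl)amino in place of 4-chloro-3-(trifluoromethyl)phenyl on an amide-type nitrogen, gives an at least 62-fold higher number from compound 2 to compound 4 (1.79 log units; beyond the scatter). The group at this place therefore has a large bearing on the read-out, and this non-ring replacement is not tolerated.

Going by these compounds, it remains open whether the loss follows from the departure of the aromatic ring or from the entering hydroxyl and carbamoyl groups. An unsubstituted phenyl, a plain propyl chain or a carboxylic acid at this place would help separate these.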